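Extending the Amide Chain in a Melatonin Receptor Ligand

The compounds below may be only part of what the source reports. "The series", "measured", "known", "first", "only" and "open" are said of these compounds alone.

Measured so far:
compound 1, `CCC(=O)NCc1cccc(OC)c1`: 22000 nM
compound 2, `COc1ccccc1CCCNC(C)=O`: 1430 nM

In an assay for binding affinity to melatonin receptor (Gallus gallus) (on this read-out lower numbers stand for stronger inhibition and higher numbers for weaker inhibition), compound 2 gives 1430 nM, the lower of the two numbers. Compound 1 gives 22000 nM, a higher number that lies well beyond the scatter. Compound 3 (`CCCC(=O)NCCCc1ccccc1OC`) differs from compound 2 by ethyl in place of hydrogen on a saturated chain carbon bound to a carbonyl carbon. Within the data shown here, no measured pair shows this change, so its effect in this assay is not known from these data. The change is expected to be modest and toward a lower number, a 2.4-fold lower number from compound 2 to compound 3 (0.38 log units; beyond the scatter). For compound 3 the estimate is 600 nM, with a range from 150 nM to 2500 nM.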

Compound 3, inhibition constant: 442 nM
Compound 3: the middle estimate sits 1.4-fold (0.13 log units) above what was measured, within the range that was stated.
By their numbers in this assay, from the lowest: compound 3; then compound 2; then compound 1.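

In this assay, putting ethyl in place of hydrogen on the saturated chain carbon bound to a carbonyl carbon gives a 3.2-fold lower number from compound 2 to compound 3 (0.51 log units; beyond the scatter) as a modest step beyond the scatter. This first measured pair at this position shows that the acyl chain can grow, from acetyl to propylcarbonyl, while the number falls rather than rises. No available evidence shows what lies behind this shift. A single step does not establish a trend with chain length. From the compounds shown here alone, whether a longer chain, a phenyl ring or an amine at this position would lower the number further remains open.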